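The source may report more compounds than this note shows. Statements on the series, on what has been measured and on what is new or still open speak of the compounds shown alone.

Measured so far, values in a functional assay on CHO cells for agonist activity at Free fatty acid receptor 1 (Rattus norvegicus), read by calcium flux; on this read-out higher numbers stand for an effect only at larger amounts of compound and lower numbers for an effect already at smaller amounts:
compound 1, `Cc1cccc(C)c1-c1cccc(COc2ccc(CCC(=O)O)s2)c1`, gives 840 nM
compound 2, `Cc1cccc(C)c1-c1cccc(COc2ccc(CCC(=O)O)c(C)n2)c1`, gives 1100 nM
compound 3, `Cc1cccc(C)c1-c1cccc(COc2ccc(CC(C)C(=O)O)cn2)c1`, gives 2100 nM

Compound 3 carries the highest of the three numbers in this assay. Its nearest neighbour is compound 2, whose number lies within the usual scatter of it, so these two cannot be placed in order; the gap to compound 1 is the only one beyond the scatter, and there compound 1 gives the lower number. All three share the same core and differ only in the ring and chain that carry the acid.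

The step to compound 4, `CCOC(CC(=O)O)c1ccc(OCc2cccc(-c3c(C)cccc3C)c2)nc1`, changes one place: 2-carboxy-1-ethoxyethyl in place of 2-carboxypropyl on an aromatic carbon. Going by the values given here, no pair of measured compounds shows a change of this kind, so there is no measured step to lean on. The acid is kept, the chain grows by the ethoxy branch, and the ring is that of compound 3. Among the compounds with values here, nothing among the measured compounds indicates that such a change moves the number far in either direction, so compound 4 is expected to stay close to compound 3, with an expected step of a 1.3-fold lower number from compound 3 to compound 4 (0.12 log units; within the scatter) that may well fall inside the scatter. The estimate for compound 4 is 1600 nM, in the range 500 nM to 5000 nM.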

Compound 4, half-maximal effective concentration: 130 nM
For compound 4 the middle estimate is 12-fold (1.09 log units) above the measured one, outside the stated range (below it).
By their numbers in this assay, from the lowest: compound 4; then compounds 1, 2 and 3 (each within the scatter of the next, the first and the last beyond it).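

Going by these compounds alone, on the aromatic carbon para to a large group, two atoms from the ring nitrogen, the chain that carries the acid turns out to be a sensitive place in this assay: 2-carboxy-1-ethoxyethyl in place of 2-carboxypropyl gives a 16-fold lower number from compound 3 to compound 4 (1.21 log units; beyond the scatter) and is the first single-place step readable. The carboxylic acid is present on both sides of this step, while the entering group is the larger of the two and holds more oxygen, so at this position a larger branched chain goes with a lower number and not a higher one. Nothing available accounts for the size of this step.

A single step cannot separate the arrival of the ethoxy branch from the loss of the methyl branch of 2-carboxypropyl. As far as these compounds go, a methoxy or propoxy group in place of the ethoxy branch would show whether the number follows the length of that branch, and it remains open whether 2-carboxy-1-ethoxyethyl gives a comparable step on the ring of compound 1 or compound 2.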